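Reshaping the amine substituent of compound 2

This account rests on a few compounds, and the source may have more. Where it says the series, first, only, none or still open, it means among the compounds named here.

Going by the values given here, compound 2 `COc1cc(/C=C/c2nc(N(C)c3ccccc3)c3sccc3n2)cc(OC)c1OC` is the only compound with an actual number in a functional assay on L02 cells (Homo sapiens) for inhibition, read by Griess assay, with stated times of 1 h and 24 h (a higher number here means a weaker inhibitor, a lower number a stronger inhibitor), where compound 2 gives 767000 nM. Compound 1 `CNc1nc(/C=C/c2cc(OC)c(OC)c(OC)c2)nc2ccsc12` returns only a limit of the assay, > 1000000 nM, in this assay. On these data alone, the step of an at least 1.3-fold lower number from compound 1 to compound 2 (0.11 log units; that floor lies within the scatter) shows that putting phenyl in place of hydrogen on a nitrogen on an aromatic ring moved the value only within the scatter, and with one end sitting at the limit of > 1000000 nM in this assay, at which 1 of the 2 values shown sits, the true size of that step remains unknown. Compound 3 `COc1cc(/C=C/c2nc(NCc3ccccc3)c3sccc3n2)cc(OC)c1OC` carries the change (benzylamino in place of methyl(phenyl)amino on an aromatic carbon); the attached group keeps the same atoms but joins them differently. Among the compounds with values here, the only measured step touching this nitrogen, an at least 1.3-fold lower number from compound 1 to compound 2 (0.11 log units; that floor lies within the scatter), was small at best, and no step beyond the scatter is expected in this assay, in either direction. Compound 3 is therefore estimated to give 800000 nM, between 300000 nM and 2000000 nM, which amounts to an expected 1.0-fold higher number from compound 2 to compound 3 (0.02 log units; within the scatter).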

Compound 3, half-maximal inhibitory concentration: > 1000000 nM
Compound 3: no number, only a limit; the forecaster's own chance of this, stated with the estimate: 35%; middle value at least 1.2-fold (0.09 log units) away from the limit.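

Swapping methyl(phenyl)amino for benzylamino on this aromatic carbon joins the same atoms differently and brings in a hydrogen-bond donor, and it gives an at least 1.3-fold higher number from compound 2 to compound 3 (0.11 log units; that floor lies within the scatter), so this rearrangement brought no readable gain in this assay. Compound 3 gives > 1000000 nM, which is a limit of the assay and not a number. The true size of the step stays unknown because one of its ends is such a limit, and most of the series now sits there: the limit of > 1000000 nM in this assay, at which 2 of the 3 values shown sit.

The step from compound 1 to compound 3 joins two limits and cannot be read. Still open, on these data alone, is whether a morpholine ring, a free amino group or a longer chain such as phenethylamino at this carbon would give a clear number in this assay.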